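A New Amide Group at the Assay Limit

The compounds below may be only part of what the source reports. "The series", "measured", "known", "first", "only" and "open" are said of these compounds alone.

Compound 1 `CCCCN(C)C(=O)CCCOc1cc(OC)c(OC)c2oc(-c3ccc(OC)cc3)c(O)c(=O)c12` and compound 2 `COc1ccc(-c2oc3c(OC)c(OC)cc(OCCCC(=O)NCc4ccccn4)c3c(=O)c2O)cc1` share one core and differ in the group on a carbonyl carbon. In a functional assay on A549 cells (Homo sapiens) for antiproliferative activity, read by sulforhodamine B assay, with a stated time of 48 h (a higher number here means a weaker inhibitor, a lower number a stronger inhibitor), compound 1 gives > 40000 nM, which is a limit of the assay and not a number. In this assay compound 2 gives > 40000 nM, which is again a limit. Compound 2 therefore offers no exact potency as a starting point.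

Compound 3 `COc1ccc(-c2oc3c(OC)c(OC)cc(OCCCC(=O)N4CCN(C)CC4)c3c(=O)c2O)cc1` keeps the core but carries 4-methylpiperazin-1-yl in place of ((pyridin-2-yl)methyl)amino on that carbonyl carbon: 4-methylpiperazin-1-yl in place of ((pyridin-2-yl)methyl)amino on a carbonyl carbon. Among the measured compounds shown here, the only measured change at this place is a step that the two limits leave unreadable from compound 1 to compound 2. The evidence so far is the limit of > 40000 nM in this assay, at which 2 of the 2 values shown sit. Neither a size nor a direction can be read from that step, so no change beyond the usual scatter can be predicted with any confidence. The estimate is a number no higher from compound 2 to compound 3 (the limit leaves the size open), an expected step with no firm direction. The expected value for compound 3 is 40000 nM, with an estimated range from 15000 nM to 80000 nM.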

Compound 3, half-maximal inhibitory concentration: > 40000 nM
Compound 3: only a limit was reported (the forecaster's own chance of this, stated with the estimate: 75%); the middle value lies on the limit itself.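

In this assay compound 3 gives > 40000 nM, again a limit of the assay and not a number. The steps to compound 3 from compound 1 and from compound 2 therefore cannot be read. The compounds shown leave open whether any group on this carbonyl carbon changes potency, as all values share one limit: the limit of > 40000 nM in this assay, at which 3 of the 3 values shown sit.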